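Swapping hydroxy for methyl on a compound with a low number in a mannosidase assay

The compounds below may be only part of what the source reports. "The series", "measured", "known", "first", "only" and "open" are said of these compounds alone.

Measured compounds:
- compound 1 `OC[C@]1(c2ccc(F)cc2)NC[C@H](O)[C@H]1O`: 6.6%
- compound 2 `Cc1ccc([C@]2(CO)NC[C@@H](O)[C@@H]2O)cc1`: 0%
- compound 3 `OC[C@]1(c2ccc(O)cc2)NC[C@H](O)[C@H]1O`: 3.4%

In an assay on isolated protein for inhibition of alpha-mannosidase (Canavalia ensiformis), tested at 1000 uM (on this read-out lower numbers stand for less inhibition and higher numbers for more inhibition at the one concentration tested (going by the name of the read-out)), compound 3 gives 3.4%, the second highest of the three numbers, yet every gap between these compounds lies within the scatter, so none can be ranked against another. Going by the values given here, the one measured step with a single change, a number 3.2 percentage points lower from compound 1 to compound 3 (within the scatter), was within the scatter. Compound 4 `Cc1ccc([C@@]2(CO)NC[C@H](O)[C@H]2O)cc1` is derived from compound 3 by a single change: methyl in place of hydroxy on an aromatic carbon. Among the compounds with values here, no measured step covers this exact swap, but the only step seen on this ring position moved nothing beyond the scatter, and all three measured numbers are low. Compound 4 is therefore expected to show a step of a number 0.4 percentage points lower from compound 3 to compound 4 (within the scatter) in this assay, that is, no change beyond the scatter. The estimate for compound 4 is 3%, within the range 0% to 12%.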

Compound 4, a percentage reported as inhibition, at one concentration (the size of the read-out at that concentration, not a potency): 0%
Estimate against measurement, compound 4: 3 percentage points above; the range from low to high includes it.
By their numbers in this assay, from the lowest: compounds 2, 4, 3 and 1 (each within the scatter of the next).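

In this assay, methyl in place of hydroxy gives a number 3.4 percentage points lower from compound 3 to compound 4 (within the scatter), and methyl in place of fluoro gives a number 6.6 percentage points lower from compound 1 to compound 4 (within the scatter), so neither swap on this aromatic carbon moves the number beyond the scatter. Inverting every stereocentre gives no change at the digits printed from compound 2 to compound 4 (within the scatter), so in this one pair the configuration as drawn shows no effect either, a comparison that rests on this: the fact that compounds 2 and 4 differ only in the configuration as drawn

The compounds shown leave open what an amine, a carboxylic acid or a longer chain on this aromatic carbon would do. They also leave open whether any group here can lift the number clear of the scatter.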